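Swapping the furan for an aminopyrazole on a fused core

A few compounds are considered here, and "the series" means these few. Any claim that something is new, unique, unknown or untested is made for them only; others in the source may bear on it.

The series shares one fused core carrying a 4-fluorophenyl group. Compound 1 `Fc1ccc(-c2nn3c(NC4CCCC4)cccc3c2-c2ccnc(F)c2)cc1` and compound 2 `Fc1ccc(-c2nn3c(NC4CCCC4)cccc3c2-c2ccco2)cc1` differ only in the ring attached alongside that group; compound 3 `Nc1nccc(-c2c(-c3ccc(F)cc3)nn3c(NC4CCCC4)cccc23)n1` carries an aminopyrimidine there instead. In an ADME assay on Vero cells (Chlorocebus sabaeus) for cytotoxicity (a higher number here means that more compound is tolerated, a lower number that less compound is tolerated), compound 3 gives 46000 nM. In this assay compound 2 gives "not determined" (no result reported). In this assay, among the measured compounds shown here, compound 1 likewise gives "not determined" (no result reported), so compound 2 stands without a measured value in this assay and no step between measured compounds is available.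

Compound 4 `Nc1n[nH]cc1-c1c(-c2ccc(F)cc2)nn2c(NC3CCCC3)cccc12` is the next member. Relative to compound 2 the change is 3-amino-1H-pyrazol-4-yl in place of furan-2-yl on an aromatic carbon. For the measured compounds named here, with no measured step to lean on, the writer expects no shift in this assay beyond the usual scatter, in either direction, from the change itself. Because compound 3 gives 46000 nM with a related amino-bearing ring, compound 4 is expected to come out near 40000 nM in this assay, within a range from 15000 nM to 100000 nM.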

Compound 4, half-maximal cytotoxic concentration: 20000 nM
The estimate for compound 4 lay 2.0-fold (0.30 log units) above the measured number; low and high end bracket the measured number.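

At the aromatic carbon next to the ring atom that bears a 4-fluorophenyl group, the first readable step shows that two amino-bearing rings are not interchangeable in this assay. Placing 3-amino-1H-pyrazol-4-yl there in place of 2-aminopyrimidin-4-yl gives a 2.3-fold lower number from compound 3 to compound 4 (0.36 log units; beyond the scatter) and this modest change lies beyond the scatter, so less of compound 4 is tolerated. Nothing shown here accounts for the shift.

The steps from compound 1 and compound 2 cannot be read, which leaves the effect of replacing furan-2-yl unresolved. Going by these compounds, it also remains open whether the shift follows the ring or its amine, a question that a pyrazol-4-yl ring without the amine, or one carrying a methylamino group instead, would address.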